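The source may report more compounds than this note shows. Statements on the series, on what has been measured and on what is new or still open speak of the compounds shown alone.

In a physicochemical assay for solubility, in phosphate buffer, measured as kinetic solubility, at pH 7.4, tested at 250 uM (on this read-out higher numbers stand for higher solubility and lower numbers for lower solubility), the measured compounds are:

- compound 1 `CN(C)S(=O)(=O)c1cc(C(=O)O)ccc1NCCCC(F)(F)F`: 245000 nM
- compound 2 `O=C(O)c1ccc(NCCCCCCCC(F)(F)F)c(S(=O)(=O)N2CCCC2)c1`: 66000 nM
- compound 3 `O=C(O)c1ccc(NCCCCCCCC(F)(F)F)c(S(=O)(=O)N2CCCCC2)c1`: 13000 nM

Of these three, compound 3 stands lowest, at 13000 nM. Compound 4 `O=C(O)c1ccc(NCCCCCCCC(F)(F)F)c(S(=O)(=O)NC2CCCCC2)c1` has not yet been measured. It has cyclohexylamino in place of piperidin-1-yl on a sulfonyl sulfur.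

For the measured compounds named here, only one measured step changes a single group at this place: a 5.1-fold lower number from compound 2 to compound 3 (0.71 log units; beyond the scatter), with piperidin-1-yl in place of pyrrolidin-1-yl. Compound 1 differs from compound 3 in more than one place, so it gives no clean comparison. Going by the values given here, no measured compound carries cyclohexylamino, so the single step is only a rough guide to size. A small downward move in this assay seems likely, no larger than that modest step and probably not beyond the scatter. The expected change is a 1.4-fold lower number from compound 3 to compound 4 (0.16 log units; within the scatter). For compound 4, the estimated value is 9000 nM, with an expected range of 2500 nM to 32000 nM.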

Compound 4, solubility: 9000 nM
Beside the measured number, compound 4's estimate shows no gap at the digits printed; the range from low to high includes it.
By their numbers in this assay, from the lowest: compounds 4 and 3 (each within the scatter of the next); then compound 2; then compound 1.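

In this assay, changing piperidin-1-yl to cyclohexylamino on the sulfonyl sulfur gives a 1.4-fold lower number from compound 3 to compound 4 (0.16 log units; within the scatter), so the two groups cannot be told apart on this read-out, even though the entering group has a ring of carbon only and 1 hydrogen-bond donor. The comparison with pyrrolidin-1-yl gives a 7.3-fold lower number from compound 2 to compound 4 (0.87 log units; beyond the scatter), so compound 2 stays clearly separate from compound 4 as well as from compound 3. Nothing shown here gives a reason for these numbers.

From the compounds shown here alone, whether this match between compound 3 and compound 4 extends to a morpholin-4-yl group or an open-chain amine such as diethylamino at this place remains open. So does whether the same swaps would give similar steps on the chain of compound 1.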